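This account rests on a few compounds, and the source may have more. Where it says the series, first, only, none or still open, it means among the compounds named here.

Compound 1 `O=C(Nc1ccccc1)Nn1c(-c2ccccc2)nc2ccccc2c1=O` and compound 2 `CCc1nc2ccccc2c(=O)n1NC(=O)Nc1ccc([N+](=O)[O-])cc1` share one core. In a functional assay on the whole organism (strain albino) with Mus musculus as the target, at a dose of 100 mg/kg by the intraperitoneal route (a lower number here means less inhibition, a higher number more inhibition at the dose given (going by the name of the read-out)), compound 1 gives 56%. In this assay compound 2 gives 41%, the lower of the two numbers, and compound 1 stands higher by a margin beyond the usual scatter. Compound 3 `CCc1nc2ccccc2c(=O)n1NC(=O)Nc1ccccc1` differs from compound 2 in one place: hydrogen in place of nitro on an aromatic carbon. Among the measured compounds shown here, no measured pair differs in just this way, so the size of that step is unknown. A modest rise is expected, a number 7 percentage points higher from compound 2 to compound 3 (within the scatter), partly since compound 1 gives 56%. Compound 3 is estimated at 48%, between 30% and 65%.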

Compound 3, a percentage reported as inhibition, in the whole organism at one dose (the size of the read-out at that dose, not a potency): 54%
Beside the measured number, compound 3's estimate is 6 percentage points below it, and the stated range covers the measured number.
By their numbers in this assay, from the lowest: compound 2; then compounds 3 and 1 (each within the scatter of the next).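

With hydrogen in place of nitro on the aromatic carbon para to a large group, a number 13 percentage points higher from compound 2 to compound 3 (beyond the scatter) in this assay, so the number at this position responds to the change. With ethyl in place of phenyl on an aromatic carbon, a number 2 percentage points lower from compound 1 to compound 3 (within the scatter), so this change leaves no difference that can be read in this assay. Nothing measured here explains either step. From the compounds shown here alone, whether an amine or a methoxy group at the nitro position would shift the number remains open. So does the effect of a longer chain in place of ethyl.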